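The source may report more compounds than this note shows. Statements on the series, on what has been measured and on what is new or still open speak of the compounds shown alone.

Measured in an ADME assay on microsomes from liver (Mus musculus) for metabolic stability, with a stated time of 10 min, tested at 0.5 uM; on this read-out lower numbers stand for a less stable compound and higher numbers for a more stable compound:
- compound 1 `Cc1noc(C)c1[C@@H]1C[C@@](C)(c2ccc(F)cc2F)N=C(N)S1`: 72%
- compound 2 `Cc1onc(-c2ccc(F)cc2)c1[C@@H]1C[C@@](C)(c2ccc(F)cc2F)N=C(N)S1`: 23%

Of these two numbers, the lower belongs to compound 2, at 23%, and the gap to compound 1 is beyond the scatter.

Next is compound 3 `Cc1onc(-c2cccnc2)c1[C@@H]1C[C@@](C)(c2ccc(F)cc2F)N=C(N)S1`, not yet measured, with pyridin-3-yl in place of 4-fluorophenyl on an aromatic carbon.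

Going by the values given here, only one measured step bears on this change: a number 49 percentage points lower from compound 1 to compound 2 (beyond the scatter). It is large and beyond the scatter, and it shows that this assay can respond strongly to a change of group at this carbon. That step replaced methyl with an aromatic ring, whereas here one aromatic ring replaces another. Among the compounds with values here, no measured pair compares these two rings, so the direction is uncertain.

A smaller, upward change is expected: a number 12 percentage points higher from compound 2 to compound 3 (beyond the scatter).

For compound 3 the estimated value is 35%, with an expected range of 15% to 60%.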

Compound 3, percent of the compound remaining: 6%
Beside the measured number, compound 3's estimate is 29 percentage points above it, and the stated range ends above it.
By their numbers in this assay, from the lowest: compound 3; then compound 2; then compound 1.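

In this assay, exchanging 4-fluorophenyl for pyridin-3-yl on this aromatic carbon, next to the ring nitrogen, gives a number 17 percentage points lower from compound 2 to compound 3 (beyond the scatter) and so shows that the identity of the aromatic ring matters, not only its presence in place of methyl. Against the methyl of compound 1, pyridin-3-yl gives a number 66 percentage points lower from compound 1 to compound 3 (beyond the scatter) and leaves compound 3 the lowest of the three, so a hetero atom in this ring does not recover the number lost on leaving methyl. Nothing at hand explains either step.

Still open, as far as these compounds go, is whether a non-aromatic group here, such as ethyl, cyclopropyl or morpholine, stays near compound 1. Also open, from the compounds shown here alone, is whether another aromatic ring, such as phenyl or pyrimidin-5-yl, would fall between or outside these values.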